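This account rests on a few compounds, and the source may have more. Where it says the series, first, only, none or still open, it means among the compounds named here.

Working notes on the series built on the shared core of compound 1 `C=C1C(=O)[C@@]23C(=O)OC[C@]4(C(=O)CCC(C)(C)[C@H]4C=O)[C@@H]2CC[C@@H]1[C@H]3OC(=O)c1ccc(C)cc1`, read in a functional assay on K562 cells (Homo sapiens) for cytotoxicity, read by MTT assay, with a stated time of 72 h; a lower number here means a stronger inhibitor, a higher number a weaker inhibitor. Compound 1 gives 1270 nM, compound 2 `C=C1C(=O)[C@@]23C(=O)OC[C@]4(C(=O)CCC(C)(C)[C@H]4C=O)[C@@H]2CC[C@@H]1[C@H]3OC(=O)c1ccc(OC)cc1` gives 1650 nM, and compound 3 `C=C1C(=O)[C@@]23C(=O)OC[C@]4(C(=O)CCC(C)(C)[C@H]4C=O)[C@@H]2CC[C@@H]1[C@H]3OC(=O)c1ccc(C(F)(F)F)cc1` gives 2820 nM. Compound 3 lies clear of compound 1 only, through a 2.2-fold higher number from compound 1 to compound 3 (0.35 log units; beyond the scatter), while a 1.7-fold higher number from compound 2 to compound 3 (0.23 log units; within the scatter) leaves it level with compound 2.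

Compound 4 `C=C1C(=O)[C@@]23C(=O)OC[C@]4(C(=O)CCC(C)(C)[C@H]4C=O)[C@@H]2CC[C@@H]1[C@H]3OC(=O)c1ccc([N+](=O)[O-])cc1` keeps the core and carries nitro in place of trifluoromethyl on an aromatic carbon, para to a large group: nitro in place of trifluoromethyl on an aromatic carbon.

Going by the values given here, no measured step makes this exact exchange. Among the compounds with values here, the three measured steps all swap the group at this same place, so they are the only guide. Besides the two above, there is a 1.3-fold higher number from compound 1 to compound 2 (0.11 log units; within the scatter). Across these swaps the largest move is the modest one between compound 1 and compound 3, and the other two stay within the scatter. As far as these compounds go, a step beyond the scatter in this assay is therefore not expected, and the direction stays open, with a slight lean towards the lower numbers of the series. The expected step is a 1.2-fold lower number from compound 3 to compound 4 (0.07 log units; within the scatter). For compound 4 the estimated value is 2400 nM, with an expected range of 1200 nM to 4600 nM.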

Compound 4, half-maximal inhibitory concentration: 1330 nM
For compound 4 the middle estimate is 1.8-fold (0.26 log units) above the measured one; low and high end bracket the measured number.
By their numbers in this assay, from the lowest: compounds 1, 4, 2 and 3 (each within the scatter of the next, the first and the last beyond it).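

Nitro in place of trifluoromethyl on this aromatic carbon in this assay gives a step that passes the scatter (a 2.1-fold lower number from compound 3 to compound 4 (0.33 log units; beyond the scatter)), the second such step at this place after (a 2.2-fold higher number from compound 1 to compound 3 (0.35 log units; beyond the scatter)), and trifluoromethyl is the group on one side of both. Compound 4 stands level with the other two compounds (a 1.2-fold lower number from compound 2 to compound 4 (0.09 log units; within the scatter); a 1.0-fold higher number from compound 1 to compound 4 (0.02 log units; within the scatter)), so methyl, methoxy and nitro are not told apart here, and compound 2 goes against a clean separation of trifluoromethyl from the rest (a 1.7-fold higher number from compound 2 to compound 3 (0.23 log units; within the scatter)). Nothing available bears on why nitro and trifluoromethyl part at this position, so the result stays an observation only.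

As far as these compounds go, all four compounds carry a benzoyl-type ester with the varied group at the one place, para to a large group, so the behaviour of the same groups elsewhere on that ring stays open. From the compounds shown here alone, whether the level reading of methyl, methoxy and nitro extends to an amine, a carboxylic acid or a longer chain at this place also stays open.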